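A few compounds are considered here, and "the series" means these few. Any claim that something is new, unique, unknown or untested is made for them only; others in the source may bear on it.

Measured so far in a functional assay on MCF7 cells (Homo sapiens) for antiproliferative activity, read by MTT assay, with a stated time of 24 h, tested at 1 ug/mL; on this read-out higher numbers stand for a weaker effect at the one concentration tested and lower numbers for a stronger effect: compound 1 `COc1cc(/C=C/C(=O)C(=Cc2cn(-c3ccccc3)nc2-c2ccccc2O)C(=O)/C=C/c2ccc(O)c(OC)c2)ccc1O` gives 88%, and compound 2 `COc1cc(/C=C/C(=O)C(=Cc2cn(-c3ccccc3)nc2-c2cccc([N+](=O)[O-])c2)C(=O)/C=C/c2ccc(O)c(OC)c2)ccc1O` gives 70%.

Among the measured compounds shown here, compound 2 stands at the lower of the two numbers; the single measured step, a number 18 percentage points lower from compound 1 to compound 2 (beyond the scatter), is a modest lowering that lies beyond the scatter. Compound 3 `COc1cc(/C=C/C(=O)C(=Cc2cn(-c3ccccc3)nc2-c2ccc(Cl)cc2)C(=O)/C=C/c2ccc(O)c(OC)c2)ccc1O` has not yet been measured. It differs from compound 2 at the same aromatic carbon of the shared core as the measured step: 4-chlorophenyl in place of 3-nitrophenyl on an aromatic carbon. For the measured compounds named here, the only step that bears on this change is a number 18 percentage points lower from compound 1 to compound 2 (beyond the scatter), which shows that exchanging the group at this position can move the read-out modestly. Going by the values given here, no measured pair, however, shows 4-chlorophenyl against 3-nitrophenyl, so the direction is uncertain. Compound 3 is therefore expected to stay near compound 2, with a step of about a number 4 percentage points higher from compound 2 to compound 3 (within the scatter) that is not clearly beyond the scatter. The estimate for compound 3 in this assay is 74%, ranging from 58% to 90%.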

Compound 3, a percentage reported as activity, at one concentration (the size of the read-out at that concentration, not a potency): 65%
Compound 3: middle estimate off by 9 percentage points, on the high side, within the range that was stated.
By their numbers in this assay, from the lowest: compounds 3 and 2 (each within the scatter of the next); then compound 1.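

In this assay the exchange of 3-nitrophenyl for 4-chlorophenyl gives a number 5 percentage points lower from compound 2 to compound 3 (within the scatter) and so does not separate the two groups, although only the group that leaves carries hydrogen-bond acceptors. The 2-hydroxyphenyl group now stands apart from a second group at this aromatic carbon: 4-chlorophenyl in its place gives a number 23 percentage points lower from compound 1 to compound 3 (beyond the scatter) and this agrees in direction with the earlier step to 3-nitrophenyl. No measurement at hand accounts for either step.

The compounds shown leave open whether a plain phenyl group or an aminophenyl group at this carbon would give a read-out in line with compound 2 and compound 3 or with compound 1. They also leave open how 4-nitrophenyl would compare with 3-nitrophenyl at the same place.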